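The source may report more compounds than this note shows. Statements on the series, on what has been measured and on what is new or still open speak of the compounds shown alone.

Three compounds have so far been measured in a functional assay on MCF7 cells (Homo sapiens) for antiproliferative activity, read by MTT assay, with a stated time of 24 h; a lower number here means a stronger inhibitor, a higher number a weaker inhibitor:

compound 1, `CCN(CC)CCNC(=O)C1CC(C(CC)(CC)c2ccc(C#CC(C)(C)O)c(C)c2)=CN1CC`, gives 3170 nM
compound 2, `CCN(CC)CCNC(=O)C1CC(C(CC)(CC)c2ccc(C#CC(C)(O)CC)c(C)c2)=CN1CC`, gives 2780 nM
compound 3, `CCN(CC)CCNC(=O)C1CC=C(C(CC)(CC)c2ccc(C#CC(C)(C)O)c(C)c2)N1CC`, gives 1490 nM

Compound 1 and compound 2 share one core and differ in a single place: methyl in place of hydrogen on a saturated chain carbon, two bonds along the chain from an oxygen on a saturated carbon and a triple-bonded carbon. That change gave a 1.1-fold lower number from compound 1 to compound 2 (0.06 log units; within the scatter), so on this core it made no real difference to the read-out.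

Compound 3 is built from the same atoms as compound 1, joined differently; how the two cores differ is not broken down here. In this assay compound 3 stands beyond the scatter from compound 1, while its gap to compound 2 lies within the scatter, so no order between compound 3 and compound 2 can be read from these numbers.

Compound 4, `CCN(CC)CCNC(=O)C1CC=C(C(CC)(CC)c2ccc(C#CC(C)(O)CC)c(C)c2)N1CC`, has not yet been measured. It stands to compound 3 as compound 2 stands to compound 1: methyl in place of hydrogen on a saturated chain carbon, two bonds along the chain from an oxygen on a saturated carbon and a triple-bonded carbon. The place of the change is the same in both pairs, so this is the same change, now made on the core of compound 3.

Because the earlier step was a 1.1-fold lower number from compound 1 to compound 2 (0.06 log units; within the scatter), the step from compound 3 to compound 4 is expected to be about as small, a 1.1-fold lower number from compound 3 to compound 4 (0.04 log units; within the scatter). Compound 4 is therefore estimated at 1350 nM, most likely between 650 nM and 2800 nM. This rests on a single earlier pair, so the expectation carries the full scatter of one measurement and more.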

Compound 4, half-maximal inhibitory concentration: 600 nM
For compound 4 the middle estimate is 2.3-fold (0.35 log units) above the measured one; measured number outside the range, below it.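

In this assay, methyl in place of hydrogen on a saturated chain carbon, the change that turns a methyl into an ethyl on the carbon carrying the hydroxyl oxygen, gave a 2.5-fold lower number from compound 3 to compound 4 (0.40 log units; beyond the scatter), a modest step that lies beyond the usual scatter, whereas on the other core the same change gave a 1.1-fold lower number from compound 1 to compound 2 (0.06 log units; within the scatter). At first sight the change seems to matter on one core and not on the other, but setting the two steps side by side does not support that reading: the same change on two cores in this assay, a 1.1-fold lower number (0.06 log units; within the scatter) from compound 1 to compound 2 and a 2.5-fold lower number (0.40 log units; beyond the scatter) from compound 3 to compound 4, 2.2-fold (0.34 log units) apart, within the scatter of two such steps. The two cores therefore cannot be said to respond differently to this change, though neither do these two pairs prove that they respond alike, and they say nothing about how the change would behave on any further core in this series.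

The compounds shown leave open whether a longer chain than ethyl at this place would lower the number further, level off or raise it again on either core. They also leave open what an amine or a methyl ether in place of the hydroxyl would do to the read-out.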